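This account rests on a few compounds, and the source may have more. Where it says the series, first, only, none or still open, it means among the compounds named here.

Going by the values given here, in an ADME assay on a cell-free system (plasma, Homo sapiens) for protein binding, the series so far holds two measured compounds. Compound 1 `O=C(O)CCc1cc(F)c(OCc2c(-c3ccc(Cl)cc3)noc2C(F)(F)F)c(F)c1` gives 99.9%, and compound 2 `O=C(O)CCc1cc(F)c(OCc2c(-c3ccccc3)noc2C(F)(F)F)c(F)c1` gives 99.8%. These values lie within the scatter of each other, so the numbers do not separate compound 2 from compound 1.

The next structure is compound 3 `CCc1ccc(-c2noc(C(F)(F)F)c2COc2c(F)cc(CCC(=O)O)cc2F)cc1`, which differs from compound 2 as follows: ethyl in place of hydrogen on an aromatic carbon. In words, this is ethyl in place of hydrogen on an aromatic carbon, para to a large group, or phenyl to 4-ethylphenyl when cut one bond further out.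

Among the compounds with values here, one measured step bears on this change. The step a 2.0-fold higher unbound fraction from compound 1 to compound 2 (0.30 log units; within the scatter) is hydrogen in place of chloro on an aromatic carbon. It is a single step with a different group, so it is only a loose guide. On that evidence, no shift beyond the scatter is expected in this assay, and any small move is expected to be towards the value of compound 1. The estimated change is a 2.0-fold lower unbound fraction from compound 2 to compound 3 (0.30 log units; within the scatter). For compound 3 the expected value is 99.9%, with an estimated range of 99.7% to 99.95%.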

Compound 3, plasma protein binding: 99.9%
For compound 3 middle estimate and measured number coincide at the digits printed; low and high end bracket the measured number.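

In this assay, the position para to a large group now carries ethyl as well as chloro and hydrogen, and the first of the new steps is a 2.0-fold lower unbound fraction from compound 2 to compound 3 (0.30 log units; within the scatter). The exchange of one substituent for the other at this position gives no change at the digits printed from compound 1 to compound 3 (within the scatter), so ethyl, a carbon group with no ring and no net charge, reads the same as chloro here, and all three compounds stand within the scatter of each other, which means this read-out does not separate hydrogen, chloro and ethyl at this place. No supporting measurement bears on why these substituents read alike.

From the compounds shown here alone, whether an amine, a hydroxyl or a longer chain at this same position would shift the unbound fraction beyond the scatter remains open. Also open is whether a change elsewhere on the shared core, such as an amide in place of the carboxylic acid, would give a step larger than any seen among these three compounds.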